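This account rests on a few compounds, and the source may have more. Where it says the series, first, only, none or still open, it means among the compounds named here.

Of the compounds shown here, three have been measured in an ADME assay on the whole organism for inhibition, with Echinochloa crus-galli var. formosensis as the target, with a stated time of 4 days (on this read-out lower numbers stand for stronger inhibition and higher numbers for weaker inhibition), so far. Compound 1, `CCN(CC)c1nc(Cl)nc(NC(C)c2ccccc2)n1`, gives 1510 nM. Compound 2, `C[C@H](Nc1nc(Cl)nc(NC(C)(C)C)n1)c1ccccc1`, gives 7410 nM. Compound 3, `CCNc1nc(Cl)nc(N[C@H](C)c2ccccc2)n1`, gives 2690 nM. On these numbers compound 3 stands second highest of the three: its value and that of compound 1 lie within the usual scatter of each other, so nothing separates them, while compound 2 lies beyond the scatter on the weaker side.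

The unmeasured compound 4, `CC(C)Nc1nc(Cl)nc(N[C@H](C)c2ccccc2)n1`, keeps the shared core of compound 3 and changes one place: methyl in place of hydrogen on a saturated chain carbon bound to a nitrogen on an aromatic ring and a saturated chain carbon. Compound 2, which carries the bulkier tert-butyl group in place of the ethyl group of compound 3, shows the weaker number, so a modest move in that direction is expected, though most likely one that stays within the scatter. For compound 4 the expected step of a 1.3-fold higher number from compound 3 to compound 4 (0.11 log units; within the scatter) is a slight weakening. The estimate for compound 4 in this assay is 3500 nM, with a range from 1500 nM to 8000 nM.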

Compound 4, half-maximal inhibitory concentration: 2000 nM
Compound 4: middle estimate off by 1.8-fold (0.24 log units), on the high side; the measured number falls inside the stated range.
By their numbers in this assay, from the lowest: compounds 1, 4 and 3 (each within the scatter of the next); then compound 2.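

In this assay, adding a methyl to the carbon on the amino nitrogen, so that ethylamino becomes isopropylamino, gives a 1.3-fold lower number from compound 3 to compound 4 (0.13 log units; within the scatter), so this change does not separate the two compounds. This single added methyl therefore does not bring the number near that of compound 2, which carries tert-butyl at this place and gives 7410 nM, while compound 4 gives 2000 nM. Nothing available here explains why this position responds in this way.

Going by these compounds, with only ethylamino, isopropylamino and tert-butyl compared at this place, it remains open how a longer straight chain such as n-propyl or a ring such as cyclopropyl would read out. On these data alone, a plain amino group at the same place, with no carbon chain, is also open.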